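A few compounds are considered here, and "the series" means these few. Any claim that something is new, unique, unknown or untested is made for them only; others in the source may bear on it.

Measured so far:
- compound 1, `COc1cc(/C=C/C2=CC(=O)CC(c3ccc(O)c(OC)c3)N2CCCO)ccc1O`: in an ADME assay on CHO-K1 cells (Cricetulus griseus) for activation, read by fluorescence, tested at 10 uM (a higher number here means a weaker effect of the compound at the concentration tested, a lower number a stronger effect), compound 1 gives 80.3%
- compound 2, `O=C(/C=C(/C=C/c1ccc(O)cc1)NCCCO)/C=C/c1ccc(O)cc1`: in this assay compound 2 gives 80.5%

Compound 2 stands at the top of the two numbers in hand, but its nearest neighbour, compound 1, sits only a gap away that lies within the scatter, so the two readings cannot be told apart. Within the data shown here, no pair among the measured compounds differs in one place, so no step size has been measured.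

The next compound is compound 3, `COCCNC(=C\C(=O)/C=C/c1ccc(O)cc1)/C=C/c1ccc(O)cc1`. It is made from compound 2 by a rearrangement of the same atoms: methoxy in place of hydroxymethyl on a saturated chain carbon, two bonds along the chain from an amine nitrogen.

Among the measured compounds shown here, with no measured step to lean on, the expectation for this assay is a step of no more than the usual scatter, in no fixed direction. Compound 3 is expected to give about 80%, between 66% and 92%. The estimate implies a step of a number 0.5 percentage points lower from compound 2 to compound 3 (within the scatter), expected to stay within the scatter.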

Compound 3, a percentage reported as activity, at one concentration (the size of the read-out at that concentration, not a potency): 75.1%
Compound 3: the middle estimate sits 4.9 percentage points above what was measured; low and high end bracket the measured number.
By their numbers in this assay, from the lowest: compounds 3, 1 and 2 (each within the scatter of the next).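

Among these compounds, this is the first step that differs in one place. In this assay, methoxy in place of hydroxymethyl on a saturated chain carbon, two bonds along the chain from an amine nitrogen, gives a number 5.4 percentage points lower from compound 2 to compound 3 (within the scatter) and so does not separate the two compounds. At this position, going from 1 hydrogen-bond donor in the leaving group to 0 hydrogen-bond donors in the entering group, with 2 heavy atoms in each, leaves the reading within the scatter, and nothing on hand bears on what lies behind the step.

From the compounds shown here alone, whether an amine or a carboxylic acid in place of the hydroxymethyl, or a longer chain, would step beyond the scatter stays open. Going by these compounds, the change rests on a single pair, so whether it reads the same on the core of compound 1 is also open.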